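Acetyl series: back to a 4-substituted phenyl

This account rests on a few compounds, and the source may have more. Where it says the series, first, only, none or still open, it means among the compounds named here.

Among the compounds with values here, compound 2 `CC(=O)N1N=C(c2ccccc2C)OC1c1ccc(Cl)c(Cl)c1` stands highest of the two numbers measured so far: in an assay on BTI cells for inhibition of Amine oxidase [flavin-containing] B (Homo sapiens), read by fluorescence and Amplex Red, with a stated time of 15 min (a higher number here means a weaker inhibitor, a lower number a stronger inhibitor), compound 2 gives 2460 nM, whereas compound 1 `CC(=O)N1N=C(c2ccc(C)cc2)OC1c1ccc(Cl)c(Cl)c1` in this assay gives 19.4 nM. Within the data shown here, the only measured step is a 130-fold higher number from compound 1 to compound 2 (2.10 log units; beyond the scatter). Compound 3 `CC(=O)N1N=C(c2ccc(Br)cc2)OC1c1ccc(Cl)c(Cl)c1` differs from compound 2 in that (4-bromophenyl in place of 2-methylphenyl on a carbon with a double bond to nitrogen). That change reverses the kind of move seen in a 130-fold higher number from compound 1 to compound 2 (2.10 log units; beyond the scatter), so a large fall in this assay is expected, bringing compound 3 back toward the level of compound 1. Compound 3 is therefore estimated at 15 nM (range 4 nM to 80 nM), which would mean a 160-fold lower number from compound 2 to compound 3 (2.21 log units; beyond the scatter).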

Compound 3, half-maximal inhibitory concentration: 67.7 nM
Estimate against measurement, compound 3: 4.5-fold (0.65 log units) below; measured number inside the range.
By their numbers in this assay, from the lowest: compound 1; then compound 3; then compound 2.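

Replacing 2-methylphenyl with 4-bromophenyl gives a 36-fold lower number from compound 2 to compound 3 (1.56 log units; beyond the scatter) in this assay and recovers most of the earlier loss, so low numbers at this position are not confined to 4-methylphenyl. The change at the aromatic carbon still registers, with a 3.5-fold higher number from compound 1 to compound 3 (0.54 log units; beyond the scatter) as a modest step. No measurement on hand accounts for either step.

Open, as far as these compounds go, is whether 2-bromophenyl would lose as much as 2-methylphenyl, which would separate the place of the group from its identity. Also open, from the compounds shown here alone, is how 4-methoxyphenyl or 4-aminophenyl would stand against 4-methylphenyl and 4-bromophenyl.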